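Swapping fluoro for methyl on the phenyl ring of a triazole series

The source may hold more compounds than are shown below. What is called first, only, known or untested is meant among the compounds shown, and "the series" means these compounds.

Measured compounds:
- compound 1 `CC1(C)[C@H]2CC[C@]1(C)N(Cc1cn(-c3cccc(F)c3)nn1)C(=O)C2`: 180 nM
- compound 2 `CC1(C)[C@H]2CC[C@]1(C)N(Cc1cn(-c3ccccc3Cl)nn1)C(=O)C2`: 70 nM
- compound 3 `CC1(C)[C@H]2CC[C@]1(C)N(Cc1cn(-c3ccc(Br)cc3)nn1)C(=O)C2`: 80 nM

All three compounds share the same core and differ only in the halophenyl group attached to the triazole nitrogen. In a functional assay on A549 cells (Homo sapiens) for inhibition, read by MTT assay, with a stated time of 24 h (on this read-out higher numbers stand for weaker inhibition and lower numbers for stronger inhibition), compound 1 gives the highest number of the three, that is, the weakest inhibition; the step of a 2.3-fold lower number from compound 1 to compound 3 (0.35 log units; beyond the scatter) and the step of a 2.6-fold lower number from compound 1 to compound 2 (0.41 log units; beyond the scatter) both lie beyond the scatter, while compound 2 and compound 3 lie within the scatter of each other.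

Compound 4 `Cc1cccc(-n2cc(CN3C(=O)C[C@@H]4CC[C@@]3(C)C4(C)C)nn2)c1` differs from compound 1 by a single change: methyl in place of fluoro on an aromatic carbon. Going by the values given here, none of the measured steps bears directly on this change, since each of them moves a halogen to another position of the ring rather than replacing the fluoro with methyl at the same position. Among the compounds with values here, with no comparable step to lean on, a number close to that of compound 1 is expected, with no step beyond the scatter in either direction. The expected step is a 1.1-fold lower number from compound 1 to compound 4 (0.05 log units; within the scatter). Compound 4 is therefore estimated at 160 nM, with a range from 70 nM to 360 nM.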

Compound 4, half-maximal inhibitory concentration: 50 nM
Compound 4: the middle estimate sits 3.2-fold (0.51 log units) above what was measured; the measured number lies below the stated range.
By their numbers in this assay, from the lowest: compounds 4, 2 and 3 (each within the scatter of the next); then compound 1.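

In this assay, the change from 3-fluorophenyl to 3-methylphenyl gives a 3.6-fold lower number from compound 1 to compound 4 (0.56 log units; beyond the scatter), so this ring carbon responds to a swap of fluoro for methyl, a change the earlier halogen-only compounds could not test. Compound 4 also does not stand apart from the other two compounds, with a 1.6-fold lower number from compound 3 to compound 4 (0.20 log units; within the scatter) and a 1.4-fold lower number from compound 2 to compound 4 (0.15 log units; within the scatter), which leaves compound 1 alone with a higher number than the other three. Nothing available here explains why this swap moves the number.

The compounds shown leave open how an amine, a carboxylic acid or a longer chain such as propyl would read in place of the methyl on this same aromatic carbon. They also leave open whether the swap of fluoro for methyl would give a similar step at other carbons of the ring.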